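This account rests on a few compounds, and the source may have more. Where it says the series, first, only, none or still open, it means among the compounds named here.

The series rests on a shared core, drawn in compound 1 `COc1ccc(/C=C/C[C@@H]2C[C@@H]([C@@H](O)c3ccc(OC)c(OC)c3)CO[C@H]2c2ccc(OC)c(OC)c2)cc1OC` and compound 2 `COc1ccc(/C=C/C[C@@H]2C[C@H]([C@H](O)c3ccc(OC)c(OC)c3)CO[C@H]2c2ccc(OC)c(OC)c2)cc1OC`. In a functional assay on HL-60 cells (Homo sapiens) for cytotoxicity, read by WST assay, with a stated time of 48 h (on this read-out higher numbers stand for weaker inhibition and lower numbers for stronger inhibition), compound 1 gives 26000 nM, while compound 2 gives "not determined" (no result reported); the two are related by the fact that compounds 1 and 2 differ only in the configuration as drawn. Compound 3 `O[C@@H](c1ccccc1)[C@H]1CO[C@H](c2ccccc2)[C@@H](C/C=C/c2cccc(F)c2)C1` carries the same core with unsubstituted phenyl groups and a 3-fluorophenyl on the propenyl chain. In this assay compound 3 gives 9170 nM, the lowest of the two numbers on hand, with compound 1 its nearest neighbour at a gap beyond the usual scatter. Compound 4 `O[C@@H](c1ccccc1)[C@H]1CO[C@H](c2ccccc2)[C@@H](C/C=C/c2ccccc2F)C1` has the same atoms as compound 3 joined differently: 2-fluorophenyl in place of 3-fluorophenyl on a double-bonded chain carbon bound to a double-bonded chain carbon. Going by these compounds, no single change of this kind has been measured here, so the size of the step is unknown. Compound 4 is expected to sit close to compound 3, with the step of a 1.2-fold higher number from compound 3 to compound 4 (0.08 log units; within the scatter) estimated to remain within the scatter in either direction. Compound 4 is therefore estimated to give 11000 nM, with a range from 4500 nM to 27000 nM.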

Compound 4, half-maximal inhibitory concentration: 9530 nM
Beside the measured number, compound 4's estimate is 1.2-fold (0.06 log units) above it; measured number inside the range.
By their numbers in this assay, from the lowest: compounds 3 and 4 (each within the scatter of the next); then compound 1.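

The series now holds its first exchange in a single place: in this assay, 2-fluorophenyl in place of 3-fluorophenyl on a double-bonded chain carbon bound to a double-bonded chain carbon gives a 1.0-fold higher number from compound 3 to compound 4 (0.02 log units; within the scatter) on this scaffold. At this place, then, the two fluorophenyl groups cannot be told apart on this read-out, so moving the fluorine around the ring from one of these named positions to the other leaves no mark that the assay resolves. The only known fact about the series concerns configuration and does not bear on this result.

Going by these compounds, whether the step stays this small with a chlorine, an amine or a carboxylic acid on that ring, or with a longer chain carrying it, remains open. Also open, on these data alone, is whether the same exchange would read alike on the core of compound 1, with its methoxy groups.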